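The source may hold more compounds than are shown below. What is called first, only, known or untested is meant among the compounds shown, and "the series" means these compounds.

Values in a functional assay on HeLa cells (Homo sapiens) for cytotoxicity, read by WST assay, with a stated time of 48 h; a higher number here means a weaker inhibitor, a lower number a stronger inhibitor:
- compound 1 `CCCCCC/C=C/C[C@H]1C[C@@H]([C@@H](O)c2ccccc2)CO[C@@H]1c1ccccc1` gives 7400 nM
- compound 2 `Oc1cccc(/C=C/C[C@H]2C[C@@H]([C@@H](O)c3ccccc3)CO[C@@H]2c2ccccc2)c1` gives 18600 nM
- compound 3 `O=[N+]([O-])c1ccc(/C=C/C[C@H]2C[C@@H]([C@@H](O)c3ccccc3)CO[C@@H]2c2ccccc2)cc1` gives 12400 nM

Only one step among these lies beyond the scatter (a 2.5-fold higher number from compound 1 to compound 2 (0.40 log units; beyond the scatter)). The two steps that reach the third compound stay within it (a 1.7-fold higher number from compound 1 to compound 3 (0.22 log units; within the scatter); a 1.5-fold lower number from compound 2 to compound 3 (0.18 log units; within the scatter)), so compound 3 cannot be told apart from either of the others.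

Compound 4 `O[C@@H](c1ccccc1)[C@H]1CO[C@H](c2ccccc2)[C@@H](C/C=C/C2CCCCC2)C1` carries cyclohexyl in place of 4-nitrophenyl on a double-bonded chain carbon bound to a double-bonded chain carbon. The entering group holds carbon only, as does the hexyl of compound 1, the closest measured comparison (7400 nM). No step beyond the scatter is therefore expected in this assay (a 1.4-fold lower number from compound 3 to compound 4 (0.14 log units; within the scatter)). For compound 4 the estimated value is 9000 nM, with an expected range from 4500 nM to 18000 nM.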

Compound 4, half-maximal inhibitory concentration: 6440 nM
Estimate against measurement, compound 4: 1.4-fold (0.15 log units) above; measured number inside the range.
By their numbers in this assay, from the lowest: compounds 4, 1, 3 and 2 (each within the scatter of the next, the first and the last beyond it).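

In this assay, going by these compounds alone, cyclohexyl, a non-aromatic ring of carbon only, gives the first step from a group at this place that exceeds the scatter while replacing an aromatic ring, a 2.9-fold lower number from compound 2 to compound 4 (0.46 log units; beyond the scatter), yet a 1.9-fold lower number from compound 3 to compound 4 (0.28 log units; within the scatter) stays within it. Against the open hexyl chain, a 1.1-fold lower number from compound 1 to compound 4 (0.06 log units; within the scatter) also stays within the scatter, so closing the carbon chain into a ring shows no separable difference here. Nothing available explains these steps.

The compounds shown leave open how an amine such as piperidinyl, or a carboxylic acid, would behave at this place. They also leave open whether a longer chain such as decyl would separate from hexyl.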